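Methoxy for Ethyl on a Core Showing No Growth Inhibition

The source may hold more compounds than are shown below. What is called first, only, known or untested is meant among the compounds shown, and "the series" means these compounds.

Compound 3 `CCc1cc(F)ccc1-c1nc(-c2ccc3[nH]c(=O)oc3c2)cs1` is one of three close relatives built on a shared core. In a functional assay on TOV21G cells (Homo sapiens) for antiproliferative activity, read by sulforhodamine B assay, with a stated time of 3 days (a higher number here means a weaker inhibitor of growth, a lower number a stronger inhibitor of growth), compound 3 gives > 50000 nM, which is a limit of the assay rather than a number. Compound 1 `Cc1cc(-c2nc(-c3ccc4[nH]c(=O)oc4c3)cs2)ccc1F` gives > 50000 nM in this assay, also a limit. Compound 2 `O=c1[nH]c2ccc(-c3csc(-c4ccc(F)c(C(F)(F)F)c4)n3)cc2o1` gives > 50000 nM in this assay, again a limit. The step that the two limits leave unreadable from compound 1 to compound 2 therefore cannot be read. Compound 4 `COc1cc(F)ccc1-c1nc(-c2ccc3[nH]c(=O)oc3c2)cs1` differs from compound 3 by methoxy in place of ethyl on an aromatic carbon. For the measured compounds named here, no measured step bears directly on this change, and every value sits at the limit of > 50000 nM in this assay, at which 3 of the 3 values shown sit. Compound 4 is thus expected to remain at that limit, with the step that the limit leaves unreadable from compound 3 to compound 4 expected to be unreadable. The estimate for compound 4 is 80000 nM, in a range from 30000 nM to 300000 nM.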

Compound 4, concentration for 50% growth inhibition: > 50000 nM
Compound 4: no number, only a limit; the forecaster's own chance of this, stated with the estimate: 85%; the middle value does not contradict the limit.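

For the compounds shown here, compound 3 and compound 4 each give only a limit, not a number, so no step between them can be read. The compounds shown leave open whether any change to the shared core brings measurable growth inhibition.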